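This account rests on a few compounds, and the source may have more. Where it says the series, first, only, none or still open, it means among the compounds named here.

Compound 1 `CCCCCCNc1nc(SCc2ccc(C(F)(F)F)cc2)nc2ccccc12` is the starting point of this set: in a functional assay on HGC-27 cells (Homo sapiens) for cytotoxicity, read by MTT assay, with a stated time of 72 h (on this read-out higher numbers stand for weaker inhibition and lower numbers for stronger inhibition), compound 1 gives 23900 nM, the highest of the two numbers recorded. Compound 3 `O=[N+]([O-])c1ccc(Nc2nc(SCc3ccc(C(F)(F)F)cc3)nc3ccccc23)cc1` gives 16600 nM, and a 1.4-fold lower number from compound 1 to compound 3 (0.16 log units; within the scatter). Compound 2 `COc1ccccc1Nc1nc(SCc2ccc(C(F)(F)F)cc2)nc2ccccc12` reaches only the assay limit, > 50000 nM; (the limit of > 50000 nM in this assay, at which 1 of the 3 values shown sits). Replacing hexyl by an aryl group thus gave an at least 2.0-fold higher number from compound 1 to compound 2 (0.32 log units; beyond the scatter) in one case and an at least 3.0-fold lower number from compound 2 to compound 3 (0.47 log units; beyond the scatter) between the two aryl cases.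

Compound 4 `COc1ccc(Nc2nc(SCc3ccc(C(F)(F)F)cc3)nc3ccccc23)cc1OC` differs from compound 1 by 3,4-dimethoxyphenyl in place of hexyl on a nitrogen on an aromatic ring. Within the data shown here, the step to compound 2 is the closest precedent, the step to compound 3 the other; together they point to a number either unchanged within the scatter or higher. Compound 4 is therefore estimated at 35000 nM (range 15000 nM to 80000 nM), a step of a 1.5-fold higher number from compound 1 to compound 4 (0.17 log units; within the scatter).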

Compound 4, half-maximal inhibitory concentration: 17900 nM
Compound 4: the middle estimate sits 2.0-fold (0.29 log units) above what was measured; the range from low to high includes it.
By their numbers in this assay, from the lowest: compounds 3, 4 and 1 (each within the scatter of the next). At a limit, above all of these: compound 2.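

In this assay, 3,4-dimethoxyphenyl on this nitrogen cannot be told apart from hexyl, a 1.3-fold lower number from compound 1 to compound 4 (0.13 log units; within the scatter), or from 4-nitrophenyl, a 1.1-fold higher number from compound 3 to compound 4 (0.03 log units; within the scatter). Methoxy groups on the aryl ring therefore do not by themselves bring the loss seen with 2-methoxyphenyl, an at least 2.7-fold lower number from compound 2 to compound 4 (0.44 log units; beyond the scatter). The value of compound 2 is a limit: the limit of > 50000 nM in this assay, at which 1 of the 4 values shown sits.

Open, going by these compounds, is whether any group here moves the number beyond the scatter of compound 1 in the stronger direction. A chain longer than hexyl, a benzyl group or a carboxylic acid on the aryl ring could test this.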